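This account rests on a few compounds, and the source may have more. Where it says the series, first, only, none or still open, it means among the compounds named here.

This study follows a small family of compounds built on one shared core. Compound 1 `O=c1c(C2N=C(c3ccccc3)SS2)coc2ccccc12` carries only hydrogen on the aromatic carbons of that core. In a functional assay on OVCAR-3 cells (Homo sapiens) for inhibition, read by sulforhodamine B assay, with a stated time of 48 h (on this read-out higher numbers stand for weaker inhibition and lower numbers for stronger inhibition), compound 1 gives > 100000 nM, which is a limit of the assay rather than a number. Compound 2 `O=c1c(C2N=C(c3ccccc3)SS2)coc2cc(Cl)ccc12` differs from it in one place, and in this assay compound 2 gives 10500 nM. That one change, chloro in place of hydrogen on an aromatic carbon, produced an at least 9.5-fold lower number from compound 1 to compound 2 (0.97 log units; beyond the scatter). Among the measured compounds shown here, compound 2 thus stands as the only compound with an actual number in this set; the one other value shown is a limit.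

Compound 3 `O=c1c(C2N=C(c3ccccc3)SS2)coc2cc(Cl)c(F)cc12` has not yet been measured. It differs from compound 2 by fluoro in place of hydrogen on an aromatic carbon. For the measured compounds named here, the only measured step concerns a different group at a different place, so it gives little direct guidance: adding a chloro gave a large step, but no step of this exact kind has been recorded. A step within the scatter, in either direction, is therefore expected, and the estimate for compound 3 is 8000 nM, between 3000 nM and 22000 nM, which amounts to an expected 1.3-fold lower number from compound 2 to compound 3 (0.12 log units; within the scatter).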

Compound 3, half-maximal inhibitory concentration: 61700 nM
Compound 3: the middle estimate sits 7.7-fold (0.89 log units) below what was measured; the whole stated range lies below it.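

In this assay, fluoro in place of hydrogen on the aromatic carbon ortho to the chloro group gave a 5.9-fold higher number from compound 2 to compound 3 (0.77 log units; beyond the scatter), the opposite direction to the earlier chloro change, which gave an at least 9.5-fold lower number from compound 1 to compound 2 (0.97 log units; beyond the scatter). The earlier compounds shown here showed only that a chloro on this part of the shared core could lower the number, whereas compound 3 shows that a second carbon of the same ring also matters and that one added fluorine atom can undo much of the lower number seen for compound 2. The size of the earlier chloro step remains a minimum, since compound 1 stands at a limit of the assay and not at an actual number: the limit of > 100000 nM in this assay, at which 1 of the 3 values shown sits.

With only hydrogen and fluoro shown at this position, it remains open whether the higher number is specific to fluoro or would follow from other groups placed there. A methoxy group or an amine on the same carbon would help to separate those two readings, and fluoro on the same carbon without the chloro would show whether the change depends on that neighbouring group.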